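Moving a fluorine on the benzoyl ring of an azo amide

A few compounds are considered here, and "the series" means these few. Any claim that something is new, unique, unknown or untested is made for them only; others in the source may bear on it.

Two compounds have been measured in a functional assay on HeLa cells (Homo sapiens) for cytotoxicity, read by MTT assay, with a stated time of 72 h; a higher number here means a weaker inhibitor, a lower number a stronger inhibitor:

Compound 1, `O=C(c1cccc(C(F)(F)F)c1)N(/N=N/c1ccc([N+](=O)[O-])cc1Br)c1ccc([N+](=O)[O-])cc1Br`, gives 1120 nM in this assay.
Compound 2, `O=C(c1ccccc1F)N(/N=N/c1ccc([N+](=O)[O-])cc1Cl)c1ccc([N+](=O)[O-])cc1Cl`, gives 2350 nM in this assay.

Of these two numbers, compound 2 carries the higher one; compound 1 has the lower number, and the gap between them lies beyond the usual scatter. Compound 2 and compound 1 differ in more than one place, so nothing can be said about which change drives the gap.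

Compound 3, `O=C(c1cccc(F)c1)N(/N=N/c1ccc([N+](=O)[O-])cc1Cl)c1ccc([N+](=O)[O-])cc1Cl`, has the same atoms as compound 2 joined differently: 3-fluorophenyl in place of 2-fluorophenyl on a carbonyl carbon, that is, (2-fluorophenyl)carbonyl becomes (3-fluorophenyl)carbonyl. Among the measured compounds shown here, no measured pair isolates such a move of a fluorine, and the only other compound, compound 1, shows a benzoyl ring bearing trifluoromethyl rather than fluorine alongside a different halogen on both aryl rings. The step from compound 2 to compound 3 in this assay is therefore expected to be small, a 1.3-fold lower number from compound 2 to compound 3 (0.12 log units; within the scatter), and not clearly beyond the scatter. Compound 3 is estimated to give 1800 nM in this assay, within a range of 700 nM to 4500 nM.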

Compound 3, half-maximal inhibitory concentration: 2500 nM
Estimate against measurement, compound 3: 1.4-fold (0.14 log units) below; the measured number falls inside the stated range.
By their numbers in this assay, from the lowest: compound 1; then compounds 2 and 3 (each within the scatter of the next).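

In this assay, among the compounds shown here, the fluorine move gives a 1.1-fold higher number from compound 2 to compound 3 (0.03 log units; within the scatter), making this the first measured pair to isolate a single change, 3-fluorophenyl in place of 2-fluorophenyl on a carbonyl carbon. The two placements of fluorine cannot be told apart in this assay, so compound 2 and compound 3 show no measurable preference between them. No accompanying measurement offers an explanation for this result.

On these data alone, what an amine, a methoxy group or a carboxylic acid would do in place of the fluorine on this benzoyl ring remains open, as does the effect of 4-fluorophenyl on the same carbonyl carbon. As far as these compounds go, it is also open whether the same fluorine move would read alike with bromine on both aryl rings, the halogen carried by compound 1.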